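A few compounds are considered here, and "the series" means these few. Any claim that something is new, unique, unknown or untested is made for them only; others in the source may bear on it.

Compounds measured so far:
- compound 1 `N[C@@H]1CCCN(c2cc(Nc3ccccc3Cl)n3nccc3n2)C1`: > 100000 nM
- compound 2 `Clc1ccc(Nc2cc(N3CCNCC3)nc3ccnn23)c(Cl)c1`: > 100000 nM

Both compounds were tested in an assay on isolated protein for inhibition of Dipeptidyl peptidase 9 (Homo sapiens); on this read-out lower numbers stand for stronger inhibition and higher numbers for weaker inhibition. For compound 1 the reported value of > 100000 nM is a limit of the assay, not a number. For compound 2 the value of > 100000 nM is likewise a limit. Within the data shown here, compound 1 therefore stands nowhere in particular on this read-out; both values shown sit at the same ceiling (the limit of > 100000 nM in this assay, at which 2 of the 2 values shown sit), so no step between measured compounds can be drawn, and no pattern beyond the two can be claimed.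

Compound 3 `N[C@@H]1CCCN(c2cc(NCc3ccccc3)n3nccc3n2)C1` is not yet measured. It differs from compound 1 by benzyl in place of 2-chlorophenyl on a nitrogen on an aromatic ring. Among the measured compounds shown here, with no measured step as a guide, the step from compound 1 to compound 3 is expected to be a number no higher from compound 1 to compound 3 (the limit leaves the size open), so none beyond the scatter. Compound 3 is thus expected at 100000 nM, in the range 20000 nM to 500000 nM.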

Compound 3, half-maximal inhibitory concentration: > 100000 nM
Compound 3 gave a limit, no number; the forecaster's own chance of this, stated with the estimate: 75%; the middle value lies on the limit itself.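

In this assay compound 3 gives > 100000 nM, which is a limit of the assay and not a number. Among these compounds, no step from compound 1 to compound 3 can be read, because both compounds sit at the same ceiling: the limit of > 100000 nM in this assay, at which 3 of the 3 values shown sit. The compounds shown leave open whether any change on the shared core would give a readable value.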